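Compound 3 and the swap from chloro to cyano

The compounds below may be only part of what the source reports. "The series", "measured", "known", "first", "only" and "open" are said of these compounds alone.

Compound 1 `CCOc1cc(NC(=O)NCc2cc(C)c(-c3cn(C)nc3C(F)(F)F)nn2)cc(C#N)n1` gives < 105 mL/min/kg as a limit
Compound 2 `CCOc1cc(NC(=O)NCc2cc(C)c(-c3cn(C)nc3C(F)(F)F)nn2)cc(C)n1` gives < 58.4 mL/min/kg as a limit
Compound 3 `CCOc1nc(C)cc(NC(=O)NCc2cc(C)c(-c3cn(C)nc3C(F)(F)F)nn2)c1Cl` gives 250 mL/min/kg as a measured number

Within the data shown here, in an ADME assay on microsomes from liver (Mus musculus) for metabolic stability, read by LC-MS, with a stated time of 4 h, tested at 1 uM (on this read-out lower numbers stand for slow clearance and higher numbers for fast clearance), compound 3 holds the only true number of the three (250 mL/min/kg) and stands highest. The other two values are limits, not numbers.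

Compound 4 `CCOc1nc(C)cc(NC(=O)NCc2cc(C)c(-c3cn(C)nc3C(F)(F)F)nn2)c1C#N` is compound 3 with cyano in place of chloro on an aromatic carbon and this carbon lies ortho to an ethoxy group and para to a methyl group. Among the measured compounds shown here, no measured step makes this exact swap.

The closest measured step, chloro in place of hydrogen on that same aromatic carbon, is an at least 4.2-fold higher number from compound 2 to compound 3 (0.63 log units; beyond the scatter) and on that ground chloro leaving is expected to take back part of the rise. A second rise is an at least 2.3-fold higher number from compound 1 to compound 3 (0.37 log units; beyond the scatter) and its starting compound also carries a cyano group, though on a different carbon. The remaining step is a step that the two limits leave unreadable from compound 1 to compound 2 and it adds nothing here.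

A lower number is therefore expected in this assay, and the reading could even come back as a limit. For the measured compounds named here, the expected move is a 2.5-fold lower number from compound 3 to compound 4 (0.40 log units; beyond the scatter) (an estimate, resting on only three compounds). Compound 4 is therefore estimated at 100 mL/min/kg (expected range 40 mL/min/kg to 220 mL/min/kg).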

Compound 4, clearance: 2270 mL/min/kg
Compound 4: the middle estimate sits 23-fold (1.36 log units) below what was measured, and the stated range ends below it.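

Among these compounds, at this carbon, ortho to an ethoxy group and para to a methyl group, the earlier compounds showed only that chloro in place of hydrogen raises the clearance number; compound 4 now shows that the choice of group matters as well, since in this assay there is a 9.1-fold higher number from compound 3 to compound 4 (0.96 log units; beyond the scatter). Set against hydrogen, the same carbon gives an at least 38-fold higher number from compound 2 to compound 4 (1.58 log units; beyond the scatter), so the three compounds that differ only here fall in a clear order, with hydrogen lowest, chloro higher and cyano highest. That last step starts from compound 2 at < 58.4 mL/min/kg, which is a limit and not a number.

Nothing in the data shown explains why cyano raises the number so much further than chloro at this carbon. As far as these compounds go, it also stays open whether this order extends to other groups on the same carbon, such as fluoro, methoxy or an amine, and whether any of them would bring the clearance back towards the low reading of compound 2.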